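This account rests on a few compounds, and the source may have more. Where it says the series, first, only, none or still open, it means among the compounds named here.

Compound 1 `O=C(NC[C@@H](O)C(=O)O)c1ccc(CN(C(=O)Nc2cccc(Br)c2)c2ccc(C3CCCCC3)cc2)cc1` and compound 2 `Cc1cc(NC(=O)N(Cc2ccc(C(=O)NC[C@@H](O)C(=O)O)cc2)[C@H]2CC[C@H](C(C)(C)C)CC2)cc(C(F)(F)F)c1` share a core that carries an aryl urea. In an in vitro assay on BHK cells for binding affinity to Glucagon receptor (Homo sapiens) (a higher number here means a weaker inhibitor, a lower number a stronger inhibitor), compound 1 gives 8 nM; in this assay compound 2 gives 10 nM. Compound 1 thus shows the lower of the two numbers, though the gap to compound 2 lies within the usual scatter, so neither stands apart. Compound 3 `CC(C)(C)c1cccc(NC(=O)N(Cc2ccc(C(=O)NC[C@@H](O)C(=O)O)cc2)c2ccc(C3CCCCC3)cc2)c1` keeps everything of compound 1 except one group: tert-butyl in place of bromo on an aromatic carbon. Among the measured compounds shown here, with no comparable step among the measured compounds, only a small shift of a 1.3-fold higher number from compound 1 to compound 3 (0.10 log units; within the scatter) is expected, not clearly beyond the scatter. Compound 3 is therefore estimated at 10 nM, with a range from 4 nM to 30 nM.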

Compound 3, half-maximal inhibitory concentration: 18 nM
Compound 3: the middle estimate sits 1.8-fold (0.26 log units) below what was measured; measured number inside the range.
By their numbers in this assay, from the lowest: compounds 1, 2 and 3 (each within the scatter of the next, the first and the last beyond it).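

The position on the aromatic ring, meta to a large group, now has its first direct comparison: replacing bromo (1 heavy atom) with tert-butyl (4 heavy atoms) gives a 2.3-fold higher number from compound 1 to compound 3 (0.35 log units; beyond the scatter) in this assay. The position therefore responds to this change, but the step is modest. No evidence at hand accounts for this step.

From the compounds shown here alone, neither group has hydrogen-bond donors or acceptors, so what an amine or a carboxylic acid would do here remains open. Going by these compounds, whether the same swap would give a similar step on another core also remains open.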